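Ethyl to propyl on the shared core: antiproliferative notes

A few compounds are considered here, and "the series" means these few. Any claim that something is new, unique, unknown or untested is made for them only; others in the source may bear on it.

Measured compounds:
compound 1, `CCn1nc(-c2ccnc(Nc3ccc(S(N)(=O)=O)cc3)n2)c2ccccc21`, 2280 nM
compound 2, `CCn1nc(-c2ccnc(Nc3cccc(S(N)(=O)=O)c3)n2)c2ccccc21`, 7260 nM
compound 3, `CCCn1nc(-c2ccnc(Nc3ccc(S(N)(=O)=O)cc3)n2)c2ccccc21`, 590 nM

All three were run in a functional assay on MCF7 cells (Homo sapiens) for antiproliferative activity, read by MTT assay, with a stated time of 72 h; on this read-out higher numbers stand for weaker inhibition of growth and lower numbers for stronger inhibition of growth. Compound 2 gives the highest number of the set; the difference between its core and that of compound 1 is not broken down here. From compound 1 to compound 3 the change is methyl in place of hydrogen on a saturated chain carbon, two bonds along the chain from an aromatic nitrogen, and it gave a 3.9-fold lower number from compound 1 to compound 3 (0.59 log units; beyond the scatter).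

Compound 4, `CCCn1nc(-c2ccnc(Nc3cccc(S(N)(=O)=O)c3)n2)c2ccccc21`, is not yet measured. It differs from compound 2 by methyl in place of hydrogen on a saturated chain carbon, two bonds along the chain from an aromatic nitrogen, the same change as that from compound 1 to compound 3. Resting on a 3.9-fold lower number from compound 1 to compound 3 (0.59 log units; beyond the scatter), a step of similar size is expected in this assay, namely a 3.6-fold lower number from compound 2 to compound 4 (0.56 log units; beyond the scatter). Compound 4 is therefore estimated at 2000 nM, with a range from 900 nM to 4500 nM.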

Compound 4, concentration for 50% growth inhibition: 4260 nM
Estimate against measurement, compound 4: 2.1-fold (0.33 log units) below; measured number inside the range.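

In this assay, the same change on the second core gives a 1.7-fold lower number from compound 2 to compound 4 (0.23 log units; within the scatter), a step that on its own cannot be told from repeat scatter. Set beside the earlier step, it does not differ measurably: the same change on two cores in this assay, a 3.9-fold lower number (0.59 log units; beyond the scatter) from compound 1 to compound 3 and a 1.7-fold lower number (0.23 log units; within the scatter) from compound 2 to compound 4, 2.3-fold (0.36 log units) apart, within the scatter of two such steps. This shows that the step is compatible with carrying over between the two cores, but it does not show that the step has the same size on both, that it is a real effect on the second core, or that it would hold on any other core.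

Open, going by these compounds, is how the number moves with a longer chain such as butyl in place of propyl. Also open, on these data alone, is how it moves with a carboxylic acid in place of the sulfonamide.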